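Amide chain length and lipophilicity in the pyridinone series

This account rests on a few compounds, and the source may have more. Where it says the series, first, only, none or still open, it means among the compounds named here.

Compound 1 `CCNC(=O)c1cc(C(=O)NC)c(=O)n(Cc2ccccc2)c1` carries two amide groups; in a physicochemical assay for lipophilicity, at pH 7.4 (a lower number here means a more polar compound, a higher number a more lipophilic compound), compound 1 gives 3. Compound 2 `CNC(=O)c1cccn(Cc2ccccc2)c1=O` gives 3 in this assay, and compound 3 `CNC(=O)c1cc(C(=O)NC(C)C)cn(Cc2ccccc2)c1=O` gives 3.6. The cores of compound 1 and compound 2 differ by hydrogen in place of ethylcarbamoyl on an aromatic carbon, and the step is no change at the digits printed from compound 1 to compound 2 (within the scatter). Within the ethylcarbamoyl series the change methyl in place of hydrogen on a saturated chain carbon bound to an amide-type nitrogen and a saturated chain carbon gave a number 0.60 log units higher from compound 1 to compound 3 (beyond the scatter). Compound 4 `CCNC(=O)c1cccn(Cc2ccccc2)c1=O` is not yet measured; it differs from compound 2 by methyl in place of hydrogen on a saturated chain carbon bound to an amide-type nitrogen. This is the same kind of change as that from compound 1 to compound 3, but not the same: there the place was bound to an amide-type nitrogen and a saturated chain carbon, here only to an amide-type nitrogen. Set beside a number 0.60 log units higher from compound 1 to compound 3 (beyond the scatter), a somewhat smaller rise is expected, a number 0.40 log units higher from compound 2 to compound 4 (beyond the scatter), because compound 2 stands at 3 and the change here reads methyl to ethyl rather than ethyl to isopropyl. Compound 4 is accordingly estimated at 3.4, between 3 and 3.8.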

Compound 4, distribution coefficient: 3.7
Beside the measured number, compound 4's estimate is 0.30 log units below it; the range from low to high includes it.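

In this assay the added methyl gives a number 0.70 log units higher from compound 2 to compound 4 (beyond the scatter) and, on the core of compound 1, the same kind of change gives a number 0.60 log units higher from compound 1 to compound 3 (beyond the scatter); both steps run in the same direction and lie beyond the scatter, so within these two pairs the change carries from one core to the other. This is one pair per core, and the places differ, as methylcarbamoyl to ethylcarbamoyl is not ethylcarbamoyl to isopropylcarbamoyl, so no general rule for the series follows. No supporting data bear on why the two steps agree.

Still open, going by these compounds, is whether a longer chain, such as propyl, on the carbamoyl nitrogen of compound 4 continues the rise. An amine or a carboxylic acid carried on that chain also remains to be placed in this assay.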